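Lengthening a dicarboxylate chain on a sugar-bearing scaffold

This account rests on a few compounds, and the source may have more. Where it says the series, first, only, none or still open, it means among the compounds named here.

Four compounds share a sugar attached to a saturated ring and carry a pair of carboxylic acids at the end of a chain. Compound 1, `CC1OC(OC2CCCCC2OCCCC(C(=O)O)C(=O)O)C(O)C(O)C1O`, and compound 2, `CC1OC(OC2CCCCC2OCCCCC(C(=O)O)C(=O)O)C(O)C(O)C1O`, differ only in that chain: 2,2-dicarboxyethyl in place of dicarboxymethyl on a saturated chain carbon, three bonds along the chain from an oxygen on a saturated carbon. Both were tested in a functional assay on HL-60 cells (Homo sapiens) for inhibition; a higher number here means a weaker inhibitor, a lower number a stronger inhibitor. For compound 1 the result is a limit of the assay, > 5000000 nM. Compound 2 likewise gives only a limit, > 5000000 nM. The step that the two limits leave unreadable from compound 1 to compound 2 is therefore unreadable, a consequence of the limit of > 5000000 nM in this assay, at which 2 of the 3 values shown sit.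

Compound 3, `CC1OC(OC2CCCCC2OC(=O)NCCCC(C(=O)O)C(=O)O)C(O)C(O)C1O`, is built on a different core, and the difference between its core and that of compound 1 is not broken down here. In this assay, among the measured compounds shown here, compound 3 gives 700000 nM, the only true number among the three. Compound 4, `CC1OC(OC2CCCCC2OC(=O)NCCCCC(C(=O)O)C(=O)O)C(O)C(O)C1O`, stands to compound 3 as compound 2 stands to compound 1: 2,2-dicarboxyethyl in place of dicarboxymethyl on a saturated chain carbon, three bonds along the chain from an amide-type nitrogen. The surroundings of the place differ, so this is the same kind of change rather than the same one.

Because the step that the two limits leave unreadable from compound 1 to compound 2 cannot be read, no measured size carries over, and the expectation is simply that compound 4 stays close to compound 3. Compound 4 is therefore expected to come out near 1000000 nM, between 300000 nM and 5000000 nM. That estimate corresponds to a step of a 1.4-fold higher number from compound 3 to compound 4 (0.15 log units; within the scatter).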

Compound 4, half-maximal inhibitory concentration: 4500000 nM
For compound 4 the middle estimate is 4.5-fold (0.65 log units) below the measured one, within the range that was stated.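

On the core of compound 3, putting 2,2-dicarboxyethyl in place of dicarboxymethyl, on a saturated chain carbon, three bonds along the chain from an amide-type nitrogen, comes with a 6.4-fold higher number from compound 3 to compound 4 (0.81 log units; beyond the scatter) in this assay, so on this core the longer chain goes with a weaker inhibitor. The same kind of change on the core of compound 1 cannot be read, because compound 1 and compound 2 both give only a limit, not a number: the limit of > 5000000 nM in this assay, at which 2 of the 4 values shown sit. The change can therefore be sized on one core only, so these compounds neither support nor contradict the idea that it carries from one core to another, and they give no reason for the weakening seen on the core of compound 3.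

The compounds shown leave open how the still longer 3,3-dicarboxypropyl and 4,4-dicarboxybutyl chains would behave on the core of compound 3, and so whether the rise in the number continues beyond a single lengthening. They also leave open how a phosphonic acid in place of the pair of carboxylic acids would compare with compound 3 at the same chain length.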